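Changing one group on a sulfonamide nitrogen

The source may hold more compounds than are shown below. What is called first, only, known or untested is meant among the compounds shown, and "the series" means these compounds.

In a functional assay on DU-145 cells (Homo sapiens) for cytotoxicity, read by trypan blue exclusion, with a stated time of 96 h (a lower number here means a stronger inhibitor, a higher number a weaker inhibitor), compound 1 `COc1cc(OC)c(/C=C/S(=O)(=O)Nc2ccc(F)c(N)c2)c(OC)c1` gives 10000 nM. Compound 2 `COc1ccc(NS(=O)(=O)/C=C/c2ccccc2OC)cc1` gives 5000 nM, and compound 3 `COc1ccc(/C=C/S(=O)(=O)Nc2ccc(OC)cc2)cc1` gives 5000 nM. These three numbers lie within the usual scatter of one another, so compound 1 cannot be separated from the other two.

Compound 4 `COc1ccc(NS(=O)(=O)/C=C/c2c(OC)cc(OC)cc2OC)cc1` has not been measured yet. It differs from compound 1 in one place: 4-methoxyphenyl in place of 3-amino-4-fluorophenyl on a sulfonamide nitrogen. In words, it has 4-methoxyphenyl in place of 3-amino-4-fluorophenyl on a sulfonamide nitrogen. Compound 3 carries the same 4-methoxyphenyl there and reads 5000 nM, but the rest of its structure differs from compound 4. Within the data shown here, no measured pair isolates this swap, so any forecast is uncertain. In this assay, I expect a moderate move toward a lower number, although a change no larger than the scatter remains possible. The expected size of the change is a 20-fold lower number from compound 1 to compound 4 (1.30 log units; beyond the scatter). For compound 4, the estimated value is 500 nM, with an expected range of 30 nM to 5000 nM.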

Compound 4, half-maximal inhibitory concentration: 200 nM
Estimate against measurement, compound 4: 2.5-fold (0.40 log units) above, within the range that was stated.
By their numbers in this assay, from the lowest: compound 4; then compounds 2, 3 and 1 (each within the scatter of the next).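

The earlier compounds shown here could say nothing about this position, since none of them formed a pair differing in one place. Here, in this assay, the group on the sulfonamide nitrogen alone gives a large change with the rest of the structure held fixed: a 50-fold lower number from compound 1 to compound 4 (1.70 log units; beyond the scatter). The two groups have the same count of heavy atoms and the same kind of aromatic ring, so the change comes with different substituents on that ring rather than a larger group, though no measurement here explains the difference.

As far as these compounds go, the swap removes the amino group and the fluorine and adds the methoxy group all at once, so their separate contributions remain unknown. From the compounds shown here alone, whether a plain phenyl group or a fluorophenyl group without the amino group would read closer to compound 1 or compound 4 also remains open.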